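Swapping methylsulfanyl for an anilino group on a fused core

This account rests on a few compounds, and the source may have more. Where it says the series, first, only, none or still open, it means among the compounds named here.

Measured in a functional assay on the whole organism (strain Wistar albino) for inhibition, with Rattus norvegicus as the target, read by paw edema, with a stated time of 1 h, at a dose of 25 mg/kg by the oral route; a higher number here means more inhibition at the dose given (going by the name of the read-out), a lower number less inhibition:
Compound 1, `CSc1nn(-c2ccccc2)c2nc(Nc3ccccc3)n(-c3ccccc3)c(=O)c12`: 46.1%
Compound 2, `CSc1nn(-c2ccc([N+](=O)[O-])cc2)c2nc(Nc3ccccc3)n(-c3ccccc3)c(=O)c12`: 42.1%

For the measured compounds named here, compound 1 stands alongside compound 2, the two numbers within the scatter of each other; the only measured step is a number 4 percentage points lower from compound 1 to compound 2 (within the scatter). Compound 3, `O=c1c2c(Nc3ccc(Cl)cc3)nn(-c3ccccc3)c2nc(Nc2ccccc2)n1-c1ccccc1`, differs from compound 1 by (4-chlorophenyl)amino in place of methylsulfanyl on an aromatic carbon. Going by the values given here, no measured step touches that group or that place, and the one step available, a number 4 percentage points lower from compound 1 to compound 2 (within the scatter), concerns another position and lies within the scatter, so it gives no direction. No step beyond the scatter is therefore expected. The expected step is a number 2.1 percentage points lower from compound 1 to compound 3 (within the scatter). Compound 3 is estimated at 44%, between 28% and 60%.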

Compound 3, a percentage reported as inhibition, in the whole organism at one dose (the size of the read-out at that dose, not a potency): 47.6%
Compound 3: the middle estimate sits 3.6 percentage points below what was measured, and the stated range covers the measured number.
By their numbers in this assay, from the lowest: compounds 2, 1 and 3 (each within the scatter of the next).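

Replacing the small methylsulfanyl on the five-membered aromatic ring with the much larger (4-chlorophenyl)amino, which brings a six-membered aromatic ring and a hydrogen-bond donor, gives in this assay a number 1.5 percentage points higher from compound 1 to compound 3 (within the scatter) at this single dose. This position therefore accepts a large change in size without a step beyond the scatter. No available evidence explains this result.

A free amine or a carboxylic acid at this position remains untested among the compounds shown. From the compounds shown here alone, whether either would shift the inhibition beyond the scatter stays open.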